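Swapping the propanoyl chain of compound 1 for a bromoalkenyl amide

The compounds below may be only part of what the source reports. "The series", "measured", "known", "first", "only" and "open" are said of these compounds alone.

Compound 1 `CCC(=O)N(Cc1ccc(OC)c(O)c1)c1cc(OC)c(OC)c(OC)c1` gives the lowest of the three numbers recorded in a functional assay on KYSE-450 cells (Homo sapiens) for inhibition, read by MTT assay, with a stated time of 48 h (on this read-out higher numbers stand for weaker inhibition and lower numbers for stronger inhibition), where compound 1 gives 98 nM. Compound 2 `COc1ccc(CNc2cc(OC)c(OC)c(OC)c2)cc1` gives 4890 nM in this assay, and compound 3 `C/C=C/C(=O)N(Cc1ccc(OC)c([N+](=O)[O-])c1)c1cc(OC)c(OC)c(OC)c1` gives 510 nM; both stand beyond the scatter from compound 1. Compound 4 `COc1ccc(CN(C(=O)/C=C/CBr)c2cc(OC)c(OC)c(OC)c2)cc1O` has not yet been measured. It differs from compound 1 in one place: 3-bromoprop-1-en-1-yl in place of ethyl on a carbonyl carbon. Among the measured compounds shown here, no measured pair shows this change on its own, so the step from compound 1 to compound 4 in this assay is expected to be small, a 1.5-fold higher number from compound 1 to compound 4 (0.18 log units; within the scatter), probably not beyond the scatter, with a slight lean toward weaker inhibition. Compound 4 is therefore estimated at 150 nM, in a range from 40 nM to 600 nM.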

Compound 4, half-maximal inhibitory concentration: 100 nM
For compound 4 the middle estimate is 1.5-fold (0.18 log units) above the measured one; low and high end bracket the measured number.
By their numbers in this assay, from the lowest: compounds 1 and 4 (each within the scatter of the next); then compound 3; then compound 2.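

In this assay, 3-bromoprop-1-en-1-yl on the carbonyl carbon in place of ethyl leaves the number within the scatter: a 1.0-fold higher number from compound 1 to compound 4 (0.01 log units; within the scatter). Among the compounds shown here, this is the first single-place reading at this position, and it shows that the site accepts this longer, bromine-bearing alkenyl group with no measurable loss of inhibition. Nothing available explains this result. As far as these compounds go, it remains open whether the bromine matters here, and whether an amine or a carboxylic acid at the end of the chain, or a longer chain, would read the same.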